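The source may report more compounds than this note shows. Statements on the series, on what has been measured and on what is new or still open speak of the compounds shown alone.

Of the compounds shown here, three of one family have been measured in a functional assay on NCI-H727 cells (Homo sapiens), read by fluorescence and BrdU incorporation, with a stated time of 48 h, tested at 25 uM; a lower number here means a stronger effect, a higher number a weaker effect of the compound at the concentration tested. Compound 1, `COc1cc(OC)c(C(=O)/C=C/c2ccc(Cl)cc2)c(OC)c1`, gives 0% in this assay . Compound 2, `COc1cccc(/C=C/C(=O)c2c(O)cc(OC)cc2OC)c1`, gives 1.4%, a number that lies within the scatter of compound 1's reading, so the two cannot be told apart. Compound 3, `COc1cc(O)c(C(=O)/C=C/c2ccccc2SC)c(OC)c1`, gives 12%, which sits beyond the scatter above compound 1. No two of these compounds differ in only one place, so no single-change step is available.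

Compound 4, `COc1cc(OC)c(C(=O)/C=C/c2ccc(F)cc2)c(OC)c1`, differs from compound 1 by fluoro in place of chloro on an aromatic carbon. With only compound 1's value of 0% as a starting point, the step of a number 3 percentage points higher from compound 1 to compound 4 (within the scatter) is expected to be none beyond the scatter. Compound 4 is therefore estimated to give 3%, with a range from 0% to 15%.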

Compound 4, a percentage reported as activity, at one concentration (the size of the read-out at that concentration, not a potency): 4.5%
Compound 4: middle estimate off by 1.5 percentage points, on the low side; low and high end bracket the measured number.
By their numbers in this assay, from the lowest: compounds 1, 2, 4 and 3 (each within the scatter of the next, the first and the last beyond it).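

Fluoro in place of chloro gives a number 4.5 percentage points higher from compound 1 to compound 4 (within the scatter) in this assay. This first single-change comparison shows that, on this aromatic carbon para to a large group, the two halogens cannot be told apart at the concentration tested. Nothing measured here bears on the reason for this result.

From the compounds shown here alone, whether an amine or a carboxylic acid on the same carbon would give a similar reading remains open. So does whether the same swap would give a similar step on a core carrying a hydroxyl group.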